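The source may hold more compounds than are shown below. What is called first, only, known or untested is meant among the compounds shown, and "the series" means these compounds.

In a functional assay on RS4-11 cells (Homo sapiens) for inhibition, read by CCK-8 assay, with a stated time of 72 h (a lower number here means a stronger inhibitor, a higher number a weaker inhibitor), three compounds with a shared core have been measured. Compound 1 (`CCN(CC)CCCNc1ccc(S(=O)(=O)NC(=O)c2ccc(N3CCN(CC4=C(c5ccc(C(F)(F)F)cc5)CC(C)(C)CC4)CC3)cc2Oc2cnc3[nH]ccc3c2)cc1[N+](=O)[O-]`) gives 3 nM, compound 2 (`CN1CCC(CNc2ccc(S(=O)(=O)NC(=O)c3ccc(N4CCN(CC5=C(c6ccc(C(F)(F)F)cc6)CC(C)(C)CC5)CC4)cc3Oc3cnc4[nH]ccc4c3)cc2[N+](=O)[O-])C1`) gives 8.3 nM, and compound 3 (`CC1(C)CCC(CN2CCN(c3ccc(C(=O)NS(=O)(=O)c4ccc(NC5CCOC5)c([N+](=O)[O-])c4)c(Oc4cnc5[nH]ccc5c4)c3)CC2)=C(c2ccc(C(F)(F)F)cc2)C1`) gives 32 nM. Compound 3 has the highest number of the three and is therefore the weakest inhibitor among them, as shown by an 11-fold higher number from compound 1 to compound 3 (1.03 log units; beyond the scatter) and a 3.9-fold higher number from compound 2 to compound 3 (0.59 log units; beyond the scatter).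

Compound 4 (`CC1(C)CCC(CN2CCN(c3ccc(C(=O)NS(=O)(=O)c4ccc(OCC5CCOC5)c([N+](=O)[O-])c4)c(Oc4cnc5[nH]ccc5c4)c3)CC2)=C(c2ccc(C(F)(F)F)cc2)C1`) differs from compound 3 at one place: (oxolan-3-yl)methoxy in place of (oxolan-3-yl)amino on an aromatic carbon. Here (oxolan-3-yl)methoxy stands in place of (oxolan-3-yl)amino on an aromatic carbon, ortho to a nitro group.

The measured steps bear on this only indirectly. Those two, together with a 2.8-fold higher number from compound 1 to compound 2 (0.44 log units; beyond the scatter), change the group carried on the nitrogen, and none of them replaces that nitrogen. Their sizes, from modest to large, come from exchanging groups that carry a diethylamino or 1-methylpyrrolidin-3-yl unit. Compound 4 keeps the oxolane ring of compound 3, so those sizes do not carry over directly. No step beyond the scatter is therefore expected in this assay, with only a slight lean towards a higher number. The expected change is a 1.3-fold higher number from compound 3 to compound 4 (0.10 log units; within the scatter). For compound 4 the estimated value is 40 nM, with an expected range from 13 nM to 120 nM.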

Compound 4, half-maximal inhibitory concentration: 47 nM
The estimate for compound 4 lay 1.2-fold (0.07 log units) below the measured number; measured number inside the range.
By their numbers in this assay, from the lowest: compound 1; then compound 2; then compounds 3 and 4 (each within the scatter of the next).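

In this assay the exchange of (oxolan-3-yl)amino for (oxolan-3-yl)methoxy on this aromatic carbon, ortho to a nitro group, gives a step that stays within the scatter (a 1.5-fold higher number from compound 3 to compound 4 (0.17 log units; within the scatter)), so the first replacement of the linking nitrogen itself leaves compound 3 and compound 4 indistinguishable, even though the hydrogen-bond donor count falls to 0. The gaps to the compounds with a second amine in the side chain remain beyond the scatter (a 5.7-fold higher number from compound 2 to compound 4 (0.75 log units; beyond the scatter) and a 16-fold higher number from compound 1 to compound 4 (1.19 log units; beyond the scatter)), so at this position the result points to the rest of the side chain, more than the linking atom, as what separates these compounds. Nothing available explains the result or any of these steps.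

The step to compound 4 changes the linking atom and adds a carbon at once, so an (oxolan-3-yl)oxy group or an ((oxolan-3-yl)methyl)amino group would be needed to separate the two changes. On these data alone, whether the oxygen link is tolerated as well alongside an amine remains open, and a 3-(diethylamino)propoxy group in place of the (3-(diethylamino)propyl)amino group of compound 1 would test that.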